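The source may report more compounds than this note shows. Statements on the series, on what has been measured and on what is new or still open speak of the compounds shown alone.

Compound 1 `CC1CCC(=NNc2ccccc2)c2ncc(C(=O)O)c(=O)n21` gives 1.2 umol/kg in a functional assay on the whole organism with Rattus norvegicus as the target; on this read-out higher numbers stand for an effect only at larger amounts of compound and lower numbers for an effect already at smaller amounts. Compound 2 `CC1CCC(=NNc2ccc(Cl)cc2Cl)c2ncc(C(=O)O)c(=O)n21` reaches only the limit of this assay, > 100 umol/kg, and no number. The step of an at least 83-fold higher number from compound 1 to compound 2 (1.92 log units; beyond the scatter) therefore rests on that limit (the limit of > 100 umol/kg in this assay, at which 1 of the 2 values shown sits). Among the compounds with values here, compound 3 `CC1CCC(=NNc2ccc(Br)cc2Cl)c2ncc(C(=O)O)c(=O)n21` is the next member; the change bromo in place of chloro on an aromatic carbon keeps the ring, the remaining chloro group and the large group unchanged, and no measured step tests a bromo group. Since the starting point is itself a limit, the step of a number no higher from compound 2 to compound 3 (the limit leaves the size open) is expected to stay within the scatter. Compound 3 is estimated at 100 umol/kg, between 30 umol/kg and 300 umol/kg, most probably again reported only as a limit.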

Compound 3, dose for 50% inhibition: > 100 umol/kg
Compound 3: no number, only a limit (the forecaster's own chance of this, stated with the estimate: 75%); the middle value sits exactly at the limit.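

In this assay compound 3 gives > 100 umol/kg, a limit and not a number. Against the plain phenyl, 4-bromo-2-chlorophenyl gives an at least 83-fold higher number from compound 1 to compound 3 (1.92 log units; beyond the scatter), so the higher number is not tied to a chloro group para to the large group. The step from chloro to bromo cannot be read, and the two halogens cannot be ranked: the limit of > 100 umol/kg in this assay, at which 2 of the 3 values shown sit.

The compounds shown leave open whether the remaining chloro group or the group para to the large group accounts for the step on its own. They also leave open what a fluoro or methoxy group would give at that place.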